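This account rests on a few compounds, and the source may have more. Where it says the series, first, only, none or still open, it means among the compounds named here.

The story so far rests on three measured compounds and one that awaits its number. Compound 1 `CCCCCCCCCCC(C)(C)C(=O)Nc1c(C)c([N+](=O)[O-])c(C)c2c1OC(C)(C)C2` gives 36 nM in an assay for inhibition of acyl-CoA:cholesterol acyltransferase (Oryctolagus cuniculus), using microsomes; a lower number here means a stronger inhibitor, a higher number a weaker inhibitor. Compound 2 `CCCCCCCCCCC1(C(=O)Nc2c(C)ccc3c2OC(C)(C)C3)CCCC1` gives 240 nM in this assay. Compound 3 `Cc1cc(C)c(NC(=O)C(C)(C)CCCCc2ccccc2)c2c1CC(C)(C)O2` gives 210 nM in this assay, which places it second highest of the three numbers; its nearest neighbour is compound 2, whose value sits within the scatter of repeated measurements, while compound 1 stands furthest off, with a number that is lower by more than the scatter allows.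

Compound 4 `Cc1ccc(OCCCCCCC(C)(C)C(=O)Nc2c(C)cc(C)c3c2OC(C)(C)C3)cc1` has not yet been measured. Compared with compound 3, the change is 2-(4-methylphenoxy)ethyl in place of phenyl on a saturated chain carbon, five bonds along the chain from a carbonyl carbon. Among the compounds with values here, no pair of measured compounds differs in one place, so no measured step guides the expectation directly. What can be said is that compound 1, which carries the longest saturated tail on the chain carbon, shows the lowest number with 36 nM, whereas compound 3 with its shorter tail shows 210 nM. On that slender footing a modest step toward a lower number is expected in this assay, of size a 1.6-fold lower number from compound 3 to compound 4 (0.21 log units; within the scatter), though it may well fall within the scatter. Compound 4 is therefore estimated at 130 nM, within a range from 40 nM to 400 nM.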

Compound 4, half-maximal inhibitory concentration: 50 nM
Beside the measured number, compound 4's estimate is 2.6-fold (0.41 log units) above it; low and high end bracket the measured number.
By their numbers in this assay, from the lowest: compounds 1 and 4 (each within the scatter of the next); then compounds 3 and 2 (each within the scatter of the next).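

In this assay, within the data shown here, putting 2-(4-methylphenoxy)ethyl in place of phenyl on this saturated chain carbon gives a 4.2-fold lower number from compound 3 to compound 4 (0.62 log units; beyond the scatter), the first step here that can be read between compounds differing in one place. It shows that the number responds to the group at this position and that a group with more heavy atoms is compatible with a lower number, but the change brings several things at once: a longer link to the ring, an oxygen that counts as a hydrogen-bond acceptor, and a methyl group on the ring. Nothing measured here explains why the number falls.

Which of those parts matters remains open, and 2-phenoxyethyl, which lacks the methyl group, or a plain carbon chain of the same length ending in phenyl, which lacks the oxygen, would begin to separate them. Also open, going by these compounds, is how the number would respond to an amine or a carboxylic acid in place of the methyl group on this ring.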